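The compounds below may be only part of what the source reports. "The series", "measured", "known", "first", "only" and "open" are said of these compounds alone.

Values in a functional assay, read by spectrophotometry, with a stated time of 6 min; on this read-out higher numbers stand for weaker inhibition and lower numbers for stronger inhibition:
- compound 1 `CCCCOc1cc(OC)c(Br)cc1C(C)=O` gives 34100000 nM
- compound 2 `CCCCCCOc1cc(OC)c(Br)cc1C(C)=O` gives 35700000 nM
- compound 3 `CCCCCCCCCCOc1cc(OC)c(Br)cc1C(C)=O` gives 34700000 nM

Compound 3 stands level with compound 1 and compound 2, since all three numbers lie within the scatter of one another. The next member, compound 4 `CCCCCCCCCCCCCCOc1cc(OC)c(Br)cc1C(C)=O`, extends the same chain on the shared core: butyl in place of hydrogen on a saturated chain carbon, ten or more bonds along the chain from an oxygen on an aromatic ring. Within the data shown here, the closest precedent is the same butyl-for-hydrogen change made nearer the oxygen, a 1.0-fold lower number from compound 2 to compound 3 (0.01 log units; within the scatter), which ends at compound 3. The two other lengthenings, a 1.0-fold higher number from compound 1 to compound 2 (0.02 log units; within the scatter) and a 1.0-fold higher number from compound 1 to compound 3 (0.01 log units; within the scatter), also bear on it. Among the measured compounds shown here, none of the three steps moves beyond the scatter, and no measured compound goes against this flat run. Whether it holds at the longer chain length has not been measured. In this assay no change beyond the scatter is therefore expected, and the expected step is a 1.0-fold higher number from compound 3 to compound 4 (0.00 log units; within the scatter), with no direction favoured. The estimate for compound 4 is 35000000 nM (expected range 24000000 nM to 50000000 nM).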

Compound 4, half-maximal inhibitory concentration: 8700000 nM
For compound 4 the middle estimate is 4.0-fold (0.60 log units) above the measured one; measured number outside the range, below it.
By their numbers in this assay, from the lowest: compound 4; then compounds 1, 3 and 2 (each within the scatter of the next).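

In this assay the chain on the shared core is no longer silent to lengthening: compounds 1, 2 and 3 stood level within the scatter, whereas butyl in place of hydrogen on a saturated chain carbon gives a 4.0-fold lower number from compound 3 to compound 4 (0.60 log units; beyond the scatter) and moves beyond it. Octyl in place of hydrogen, six bonds along the chain from an oxygen on an aromatic ring, gives a 4.1-fold lower number from compound 2 to compound 4 (0.61 log units; beyond the scatter) and so reaches compound 4 by a step of similar size, which places the only shift beyond the scatter in this series at compound 4. No data at hand bear on the cause of this shift.

Going by these compounds, whether the lower numbers continue past compound 4 remains open. A longer chain, or a chain carrying an amine or a carboxylic acid, would show whether the trend extends and whether it depends on an unsubstituted saturated chain.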